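Three Cinnamate Nitrate Esters Reach Only a Limit

The source may report more compounds than this note shows. Statements on the series, on what has been measured and on what is new or still open speak of the compounds shown alone.

Three cinnamate nitrate esters were tested in a functional assay on HOP-62 cells (Homo sapiens) for cytotoxicity, read by resazurin assay, with a stated time of 72 h; a higher number here means a weaker inhibitor, a lower number a stronger inhibitor. Compound 1 `COc1cc(/C=C/C(=O)OCCCO[N+](=O)[O-])ccc1OCCCO[N+](=O)[O-]` reaches only the limit of > 50000 nM. Compound 3 `COc1cc(/C=C/C(=O)OCCCCCCO[N+](=O)[O-])ccc1OCCCCCCO[N+](=O)[O-]` likewise stops at the limit, > 50000 nM. Compound 2 `O=C(/C=C/c1ccc(OCCCCCCO[N+](=O)[O-])c(O)c1)OCCCCCCO[N+](=O)[O-]` also gives no number but only the limit of > 50000 nM. From compound 3 to compound 2 the change is hydrogen in place of methyl on an oxygen on an aromatic ring, and the resulting step that the two limits leave unreadable from compound 3 to compound 2 cannot be read because of the limit of > 50000 nM in this assay, at which 3 of the 3 values shown sit. The difference between the core of compound 1 and the core of compound 3 is not broken down here. Compound 4 `O=C(/C=C/c1ccc(OCCCO[N+](=O)[O-])c(O)c1)OCCCO[N+](=O)[O-]` is not yet measured; it differs from compound 1 by hydrogen in place of methyl on an oxygen on an aromatic ring, the same change as before. Because the limit of > 50000 nM in this assay, at which 3 of the 3 values shown sit, holds for every compound measured, compound 4 is expected near 80000 nM, between 30000 nM and 300000 nM. The expected step, a step that the limit leaves unreadable from compound 1 to compound 4, is therefore estimated to be small.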

Compound 4, half-maximal inhibitory concentration: 10000 nM
The estimate for compound 4 lay 8.0-fold (0.90 log units) above the measured number; measured number outside the range, below it.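

In this assay, methoxy to hydroxy gives an at least 5.0-fold lower number from compound 1 to compound 4 (0.69 log units; beyond the scatter), so on the core of compound 1 the change lowers the number beyond the scatter. The same change on the core of compound 3, leading to compound 2, cannot be read, and so the two cores cannot be compared: the limit of > 50000 nM in this assay, at which 3 of the 4 values shown sit. The series therefore shows the change working on one core only, and it does not show whether that result carries over to the other core.

The compounds shown leave open how the number would move with an amine or a carboxylic acid in place of the hydroxy. They also leave open what a longer chain carrying the nitrate ester would do.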